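The compounds below may be only part of what the source reports. "The series", "measured", "known", "first", "only" and "open" are said of these compounds alone.

Compound 1 `CCCCCCCCCCc1ccc(-c2noc([C@@H]3CCCN3)n2)cc1` is the starting point here. Among the compounds with values here, in an assay on HeLa cells for inhibition of sphingosine-1-phosphate transporter SPNS2 (Mus musculus), read by LC-MS, tested at 2 uM (a lower number here means less inhibition, a higher number more inhibition at the concentration tested (going by the name of the read-out)), compound 1 gives 21%, the lowest of the three numbers measured so far. Two other compounds share its core but carry a different group on the same aromatic carbon. Compound 2 `CCCCCCCCCCc1ccc(-c2noc(CC(O)CN)n2)cc1` gives 59% in this assay, and compound 3 `CCCCCCCCCCc1ccc(-c2noc([C@@H](N)CCCCN)n2)cc1` gives 43%.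

Compound 4 `CCCCCCCCCCc1ccc(-c2noc(CC(O)CN3CCCCC3)n2)cc1` has not yet been measured. It differs from compound 1 in one place: 2-hydroxy-3-(piperidin-1-yl)propyl in place of pyrrolidin-2-yl on an aromatic carbon. Within the data shown here, two measured steps bear on this change, since both also swap out the pyrrolidin-2-yl group of compound 1 for an open chain carrying an amine. Replacing it with 3-amino-2-hydroxypropyl gave a number 38 percentage points higher from compound 1 to compound 2 (beyond the scatter), and replacing it with 1,5-diaminopentyl gave a number 22 percentage points higher from compound 1 to compound 3 (beyond the scatter). Both steps raised the inhibition beyond the scatter, the first one strongly. Among the measured compounds shown here, compound 4 keeps the 2-hydroxypropyl chain of compound 2 but the amine now sits inside a piperidin-1-yl ring, and no measured pair shows what that does. A rise in the same direction is therefore expected, though with wide uncertainty, so for compound 4 the expected value is 50%, somewhere between 25% and 75%, which would mean an estimated step of a number 29 percentage points higher from compound 1 to compound 4 (beyond the scatter).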

Compound 4, a percentage reported as inhibition, at one concentration (the size of the read-out at that concentration, not a potency): 2%
The estimate for compound 4 lay 48 percentage points above the measured number; measured number below the stated range.
By their numbers in this assay, from the lowest: compound 4; then compound 1; then compound 3; then compound 2.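

Keeping the 2-hydroxypropyl chain and putting piperidin-1-yl in place of amino gives a number 57 percentage points lower from compound 2 to compound 4 (beyond the scatter) in this assay and is the clearest new finding, since it shows that the chain alone does not secure inhibition at this position and that the group on its nitrogen matters greatly. The earlier compounds shown here suggested that replacing pyrrolidin-2-yl with an open chain carrying an amine raises the number, but compound 4 goes against that pattern: the change to 2-hydroxy-3-(piperidin-1-yl)propyl gives a number 19 percentage points lower from compound 1 to compound 4 (beyond the scatter) and sets it well under the other open-chain compound, with a number 41 percentage points lower from compound 3 to compound 4 (beyond the scatter) for the swap from 1,5-diaminopentyl. Nothing available explains why the piperidine ring has this effect.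

Going by these compounds, it remains open whether the drop comes with the ring itself or with any added carbon on the nitrogen, which a methylamino or dimethylamino group on the same chain would help separate. The part played by the hydroxyl group is also unsettled, and a plain 3-aminopropyl chain would test it directly.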